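The source may report more compounds than this note shows. Statements on the series, on what has been measured and on what is new or still open speak of the compounds shown alone.

Compound 1 `CNC[C@]1(OC)Cc2ccccc2[C@@H]1Oc1ccccc1C`, compound 2 `CNC[C@]1(O)Cc2ccccc2[C@@H]1Oc1ccc(O)cc1C` and compound 3 `CNC[C@]1(O)Cc2ccccc2[C@@H]1Oc1ccccc1Cl` share one core and differ only in the groups on the aryl ether and at the ring carbon that carries the methylaminomethyl arm. In an in vitro assay on HEK293 cells for inhibition of sodium-dependent dopamine transporter (Homo sapiens) (a lower number here means a stronger inhibitor, a higher number a weaker inhibitor), compound 1 reaches only the limit of the assay, > 10000 nM. In this assay compound 2 gives 5000 nM. In this assay compound 3 gives 10000 nM. Of the two actual numbers, compound 3 holds the higher one, but its gap to compound 2 sits within the scatter, so no order between the two can be stated. The remaining value, that of compound 1, is a limit (the limit of > 10000 nM in this assay, at which 1 of the 3 values shown sits).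

Compound 4 `CNC[C@]1(O)Cc2ccccc2[C@@H]1Oc1ccccc1-c1cccc2ccccc12` is the next member. Against compound 3 it carries naphthalen-1-yl in place of chloro on an aromatic carbon, the naphthalen-1-yl entering on an aromatic carbon of a six-membered aromatic ring of carbon only, ortho to a large group. Among the compounds with values here, no pair of measured compounds shows a change of this kind, so the size of the step has no precedent here; the two numbers at hand both sit at the weak end of this assay. The step from compound 3 to compound 4 is expected to be a 2.5-fold lower number from compound 3 to compound 4 (0.40 log units; beyond the scatter), a modest lowering that may still fall within the scatter. Compound 4 is therefore estimated at 4000 nM, with a range from 600 nM to 20000 nM.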

Compound 4, half-maximal inhibitory concentration: 10000 nM
Compound 4: the middle estimate sits 2.5-fold (0.40 log units) below what was measured; the range from low to high includes it.
By their numbers in this assay, from the lowest: compounds 2, 3 and 4 (each within the scatter of the next).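

Replacing chloro with naphthalen-1-yl on this aromatic carbon, ortho to a large group, gives no change at the digits printed from compound 3 to compound 4 (within the scatter) in this assay. Within the data shown here, this is the first single change that can be read, and it shows that a much larger entering group, with 10 heavy atoms and 2 six-membered aromatic rings of carbon only, leaves the value at the weak end of this assay, with no gain in inhibition. The flat step carries limited weight at this end of the scale, where compound 1 is a limit and not a number: the limit of > 10000 nM in this assay, at which 1 of the 4 values shown sits.

Whether any group on this aromatic carbon can move the series away from the weak end remains open, as chloro and naphthalen-1-yl form the only single-change pair here, and neither an amine nor a carboxylic acid at this place appears among the compounds shown. On these data alone, the separate effects of the other changes also remain open, as compound 1 and compound 2 each differ from compound 3 in more than one place.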